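Removing the Octylsulfanyl Group: What Cytotoxicity to Expect

A few compounds are considered here, and "the series" means these few. Any claim that something is new, unique, unknown or untested is made for them only; others in the source may bear on it.

Compound 1 `CC1=CCC[C@H]2[C@](C)(CC3=CC(=O)C=C(Sc4ccccc4)C3=O)[C@@H](C)CC[C@]12C`: "not determined" (no result reported) in an ADME assay on PBMC cells (Homo sapiens) for cytotoxicity, read by MTT assay; a higher number here means a weaker inhibitor, a lower number a stronger inhibitor
Compound 2 `CC1=CCC[C@H]2[C@](C)(CC3=CC(=O)C(Sc4ccccc4)=CC3=O)[C@@H](C)CC[C@]12C`: 9900 nM
Compound 3 `CCCCCCCCSC1=CC(=O)C(C[C@]2(C)[C@@H](C)CC[C@]3(C)C(C)=CCC[C@@H]23)=CC1=O`: "not determined" (no result reported)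

Compound 3 stands without a number in this assay, and compound 1 is likewise without one, so within the shared core only compound 2 gives a measured value, 9900 nM. Compound 4 `CC1=CCC[C@H]2[C@](C)(CC3=CC(=O)C=CC3=O)[C@@H](C)CC[C@]12C` is the unmeasured partner of compound 3; the two differ by hydrogen in place of octylsulfanyl on a double-bonded ring carbon. Since no measured step of this kind exists among these compounds, the size of the shift in this assay cannot be read from the data; a moderate shift toward a stronger inhibitor is expected for compound 4, though its direction is uncertain and anything within the usual scatter would not surprise. Compound 4 is estimated at 5000 nM, with a range from 1500 nM to 20000 nM.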

Compound 4, half-maximal inhibitory concentration: 4800 nM
Estimate against measurement, compound 4: 1.0-fold (0.02 log units) above; the range from low to high includes it.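

In this assay, within the data shown here, the first measured change at this position is a 2.1-fold lower number from compound 2 to compound 4 (0.31 log units; beyond the scatter) so compound 4, with hydrogen on this double-bonded ring carbon, reads as modestly the stronger inhibitor of the pair. A phenylsulfanyl group here is therefore not required for the cytotoxicity seen. Nothing available explains this step.

Any step involving compound 3 or compound 1 cannot be read, so the effect of octylsulfanyl remains unknown. Going by these compounds, whether an amine or a carboxylic acid on this carbon would raise or lower the number also remains open.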